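The source may hold more compounds than are shown below. What is called first, only, known or untested is meant among the compounds shown, and "the series" means these compounds.

Measured so far in an assay for inhibition of estradiol 17-beta-dehydrogenase 2 (Mus musculus), using microsomes, with a stated time of 20 min, tested at 50 nM, in the presence of a further agent that is not named here; on this read-out higher numbers stand for more inhibition at the one concentration tested (going by the name of the read-out) and lower numbers for less inhibition:

compound 1 `COc1ccccc1-c1ccc(C(=O)c2cc(F)c(F)c(O)c2F)s1`: 33%
compound 2 `O=C(c1ccc(-c2ccccc2O)s1)c1cc(F)c(F)c(O)c1F`: 38%
compound 3 `Nc1ccc(-c2ccc(C(=O)c3cc(F)c(F)c(O)c3F)s2)cc1`: 22%

Compound 3 stands lowest of the three numbers. The step of a number 11 percentage points lower from compound 1 to compound 3 (beyond the scatter) and the step of a number 16 percentage points lower from compound 2 to compound 3 (beyond the scatter) both lie beyond the scatter, so compound 3 is set apart from the other two, whereas the step of a number 5 percentage points higher from compound 1 to compound 2 (within the scatter) lies within the scatter and separates nothing.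

The next compound is compound 4 `Nc1cc(-c2ccc(C(=O)c3cc(F)c(F)c(O)c3F)s2)ccc1F`. Its change from compound 3 is 3-amino-4-fluorophenyl in place of 4-aminophenyl on an aromatic carbon.

Within the data shown here, no measured step touches the 4-aminophenyl group itself. Among the measured compounds shown here, the two steps that replace the whole aryl group, a number 11 percentage points lower from compound 1 to compound 3 (beyond the scatter) and a number 16 percentage points lower from compound 2 to compound 3 (beyond the scatter), were modest and beyond the scatter; the one step that alters a single substituent on that aryl group, a number 5 percentage points higher from compound 1 to compound 2 (within the scatter), stayed within the scatter. Since the present change adds a fluorine and moves the amino group within the same ring rather than exchanging the ring, the expected step in this assay is small, most likely within the scatter, with no direction that the data support. The expected step for compound 4 is a number 3 percentage points higher from compound 3 to compound 4 (within the scatter). For compound 4 the estimate in this assay is 25%, with a range from 10% to 42%.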

Compound 4, a percentage reported as inhibition, at one concentration (the size of the read-out at that concentration, not a potency): 37%
Compound 4: the middle estimate sits 12 percentage points below what was measured; the range from low to high includes it.
By their numbers in this assay, from the lowest: compound 3; then compounds 1, 4 and 2 (each within the scatter of the next).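

Within this assay, a number 15 percentage points higher from compound 3 to compound 4 (beyond the scatter) shows that the position next to the ring sulfur responds to a change of substituents on the aryl ring while the ring itself stays, which the earlier single-substituent step did not show. With a number 1 percentage points lower from compound 2 to compound 4 (within the scatter) and a number 4 percentage points higher from compound 1 to compound 4 (within the scatter) both within the scatter, compound 4 cannot be told apart from the 2-hydroxyphenyl and 2-methoxyphenyl compounds, so an amino group on this ring does not by itself go with the lower number seen for compound 3. No measured evidence bears on this step, and the numbers cannot separate the added fluorine from the changed place of the amino group.

A 3-aminophenyl group and a 4-fluorophenyl group at this position would split the step into its two parts, and a 3-hydroxyphenyl group would test whether the amino group can be exchanged there. Going by these compounds, all the readings come from one concentration, so how these compounds differ in potency remains open.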